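Swapping an Ethylsulfanyl Group for a Second Hexylamino Chain

The source may report more compounds than this note shows. Statements on the series, on what has been measured and on what is new or still open speak of the compounds shown alone.

Of the compounds shown here, two built on the same fused core have been measured so far. Compound 1 `CCCCCNc1nc(SCC)nc2ncccc12` carries a pentylamino chain and an ethylsulfanyl group; in a functional assay on T-24 cells (Homo sapiens) for cytotoxicity, read by neutral red uptake, with a stated time of 72 h (a higher number here means a weaker inhibitor, a lower number a stronger inhibitor), compound 1 gives 4300 nM. Compound 2 `CCCCCCNc1nc(SCC)nc2ncccc12` lengthens that chain by one carbon, and in this assay compound 2 gives 5900 nM. Among the measured compounds shown here, the only measured step, a 1.4-fold higher number from compound 1 to compound 2 (0.14 log units; within the scatter), is small, so on the two numbers available compound 2 stands at the higher end but within the scatter of compound 1.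

Compound 3 `CCCCCCNc1nc(NCCCCCC)c2cccnc2n1` differs from compound 2 in a different place: hexylamino in place of ethylsulfanyl on an aromatic carbon. For the measured compounds named here, no measured step involves this swap; the single step from compound 1 to compound 2 concerns chain length only, and it says nothing about replacing ethylsulfanyl with hexylamino. The expectation therefore rests on little more than the level of compound 2, and it carries a wide range. In this assay compound 3 is expected to give about 5000 nM, with a range from 1500 nM to 20000 nM. That estimate means a step of a 1.2-fold lower number from compound 2 to compound 3 (0.07 log units; within the scatter), which is expected to stay close to the scatter rather than beyond it.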

Compound 3, half-maximal inhibitory concentration: 4600 nM
The estimate for compound 3 lay 1.1-fold (0.04 log units) above the measured number, and the stated range covers the measured number.
By their numbers in this assay, from the lowest: compounds 1, 3 and 2 (each within the scatter of the next).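

On an aromatic carbon between two ring nitrogen atoms, ethylsulfanyl (3 heavy atoms, 0 hydrogen-bond donors) gives way to hexylamino (7 heavy atoms, 1 hydrogen-bond donor), and this assay shows a 1.3-fold lower number from compound 2 to compound 3 (0.11 log units; within the scatter). Among the compounds shown here, this is the first look at a position that the earlier chain-length step did not touch, and here a sulfur-linked group can be exchanged for a larger nitrogen-linked chain without moving the number beyond the scatter. Nothing available explains why the swap leaves the reading within the scatter.

From the compounds shown here alone, whether a small amine such as methylamino, a carboxylic acid or a longer chain such as octylamino at this position would move the number beyond the scatter remains open. With only ethylsulfanyl and hexylamino shown here, the tolerance seen for this one swap cannot be extended to other groups, and it remains unknown which change to these compounds, if any, would produce a clear difference in this cell assay.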